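Swapping a chlorophenyl for a methylpyridinyl: what to expect

The source may hold more compounds than are shown below. What is called first, only, known or untested is meant among the compounds shown, and "the series" means these compounds.

Three compounds have been measured in a physicochemical assay for lipophilicity, read by HPLC, at pH 7.5; a higher number here means a more lipophilic compound, a lower number a more polar compound:
compound 1, `CC[C@@H](Nc1c(C#N)c(-c2ccc(-c3cccc(OC)c3)cc2)nc2cnccc12)C(N)=O`, gives 2.7
compound 2, `CC[C@@H](Nc1c(C#N)c(-c2ccc(-c3ccccc3N(C)C)cc2)nc2cnccc12)C(N)=O`, gives 3.2
compound 3, `CC[C@@H](Nc1c(C#N)c(-c2ccc(-c3ccccc3Cl)cc2)nc2cnccc12)C(N)=O`, gives 2.9

Compound 3 sits second highest of the three: against compound 1 it reads a number 0.20 log units higher from compound 1 to compound 3 (within the scatter), and against compound 2 it reads a number 0.30 log units lower from compound 2 to compound 3 (within the scatter), both within the scatter. Within the data shown here, only the step of a number 0.50 log units higher from compound 1 to compound 2 (beyond the scatter) is beyond it.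

Compound 4, `CC[C@@H](Nc1c(C#N)c(-c2ccc(-c3cnccc3C)cc2)nc2cnccc12)C(N)=O`, has not been measured in this assay. It differs from compound 3 in one place: 4-methylpyridin-3-yl in place of 2-chlorophenyl on an aromatic carbon.

The steps from compound 1 to compound 3 and from compound 2 to compound 3 change the group at this same position, and both were small. None of them, however, brings in a ring with a hetero atom or a hydrogen-bond acceptor where the leaving group had none, so they give no direct size for this change. On the counted difference alone, compound 4 is expected to read lower in this assay, the estimated step being a number 1.00 log units lower from compound 3 to compound 4 (beyond the scatter). For compound 4 the estimate is 1.9, expected to lie between 1.4 and 2.4.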

Compound 4, distribution coefficient: 2
Compound 4: middle estimate off by 0.10 log units, on the low side; the range from low to high includes it.
By their numbers in this assay, from the lowest: compound 4; then compounds 1, 3 and 2 (each within the scatter of the next, the first and the last beyond it).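

In this assay, among these compounds, this position proves able to carry a change beyond the scatter: 4-methylpyridin-3-yl in place of 2-chlorophenyl gives a number 0.90 log units lower from compound 3 to compound 4 (beyond the scatter), whereas the earlier steps to compound 3 stayed within it. The fall does not depend on a single comparison, since a number 1.20 log units lower from compound 2 to compound 4 (beyond the scatter) and a number 0.70 log units lower from compound 1 to compound 4 (beyond the scatter) are also beyond the scatter, which places compound 4 lowest of the four. It is also the only one of the four whose group here has a hetero atom in its ring, although one such example cannot establish a pattern.

The change brings in the ring nitrogen and exchanges chlorine for methyl at once, and the compounds shown include neither a 2-methylphenyl nor a plain pyridin-3-yl group that could separate the two. No measurement given here bears on why the number falls.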